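Inverting one stereocentre of compound 3

The source may hold more compounds than are shown below. What is called first, only, known or untested is meant among the compounds shown, and "the series" means these compounds.

Compound 1 `CCOC(=O)[C@@]1(C(=O)Nc2ccccc2Cl)C[C@@H]1c1cc(OC)c(OC)c(OC)c1`: 46700 nM
Compound 2 `CCOC(=O)[C@@]1(C(=O)NCc2ccc(C)cc2)C[C@H]1c1cc(OC)c(OC)c(OC)c1`: > 100000 nM
Compound 3 `CCOC(=O)[C@]1(C(=O)Nc2ccccc2Cl)C[C@H]1c1cc(OC)c(OC)c(OC)c1`: 25600 nM

These values come from a functional assay on SW480 cells (Homo sapiens) for cytotoxicity, read by MTT assay, with a stated time of 48 h; on this read-out higher numbers stand for weaker inhibition and lower numbers for stronger inhibition. Compound 3, at 25600 nM, stands level, within the scatter, with its mirror image, compound 1. For compound 2 the value > 100000 nM is a limit of the assay and not a number.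

Compound 4 `CCOC(=O)[C@@]1(C(=O)Nc2ccccc2Cl)C[C@H]1c1cc(OC)c(OC)c(OC)c1` has not yet been measured. Set against compound 3, it shows (the two compounds have the same atoms and bonds and differ only in configuration as drawn: 1 of 2 stereo elements differ; a stereocentre at a saturated ring carbon is drawn R in compound 3 and S in compound 4). Going by the values given here, only one measured step bears on this change: a 1.8-fold lower number from compound 1 to compound 3 (0.26 log units; within the scatter). That step concerns (the fact that compounds 1 and 3 differ only in the configuration as drawn), with both stereocentres inverted, and it stays within the scatter. Among the compounds with values here, no measured step inverts a single stereocentre, so the evidence is thin. Even so, no step beyond the scatter is expected in this assay, and no direction can be favoured with confidence. The estimated change is a 1.4-fold higher number from compound 3 to compound 4 (0.14 log units; within the scatter). For compound 4 the expected value is 35000 nM, with an estimated range from 12000 nM to 100000 nM.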

Compound 4, half-maximal inhibitory concentration: 30100 nM
Compound 4: middle estimate off by 1.2-fold (0.07 log units), on the high side, within the range that was stated.
By their numbers in this assay, from the lowest: compounds 3, 4 and 1 (each within the scatter of the next). At a limit, above all of these: compound 2.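

With one stereocentre inverted on its own, in this assay the shift is a 1.2-fold higher number from compound 3 to compound 4 (0.07 log units; within the scatter), and against compound 1 the same kind of single inversion gives a 1.6-fold lower number from compound 1 to compound 4 (0.19 log units; within the scatter), so neither single inversion moves the number beyond the scatter, just as the double inversion did not. For compound 2 the value > 100000 nM is a limit of the assay and not a number. Even so, compound 4 gives the first step beyond the scatter at the amide-type nitrogen, with 2-chlorophenyl in place of 4-methylbenzyl: an at least 3.3-fold lower number from compound 2 to compound 4 (0.52 log units; beyond the scatter).

On these data alone, whether configuration matters as little with 4-methylbenzyl on that nitrogen remains open. So does the effect of changes elsewhere, such as a carboxylic acid in place of the ethyl ester or an unsubstituted phenyl in place of 2-chlorophenyl.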